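The source may report more compounds than this note shows. Statements on the series, on what has been measured and on what is new or still open speak of the compounds shown alone.

Measured so far:
compound 1, `O=C(Nc1cccc(-n2cc(-c3ccncc3)c(-c3ccc(Cl)c(O)c3)n2)c1)Nc1ccc(Cl)c(Cl)c1`, 930 nM in a functional assay on UACC-257 cells (Homo sapiens) for inhibition, read by sulforhodamine B assay, with a stated time of 48 h; on this read-out lower numbers stand for stronger inhibition of growth and higher numbers for weaker inhibition of growth;
compound 2, `COc1cc(-c2nn(-c3cccc(NC(=O)c4ccc(Cl)c(C(F)(F)F)c4)c3)cc2-c2ccncc2)ccc1Cl`, 7130 nM;
compound 3, `COc1cc(-c2nn(-c3cccc(NC(=O)Nc4ccc(Cl)c(C(F)(F)F)c4)c3)cc2-c2ccncc2)ccc1Cl`, 1210 nM.

Compound 3 stands second highest of the three numbers, close to compound 1 and well apart from compound 2. Within the data shown here, the only measured step, a 5.9-fold lower number from compound 2 to compound 3 (0.77 log units; beyond the scatter), concerns the linker and says nothing about the change now at hand. Compound 4, `O=C(Nc1cccc(-n2cc(-c3ccncc3)c(-c3ccc(Cl)c(O)c3)n2)c1)Nc1ccc(Cl)c(C(F)(F)F)c1`, differs from compound 3 in one place: hydrogen in place of methyl on an oxygen on an aromatic ring. Among the measured compounds shown here, no measured pair isolates this change; compound 1 carries the hydroxy group but also a different aryl on the urea, and its value and that of compound 3 sit within the scatter of each other. The account therefore expects no step beyond the scatter, a 1.2-fold lower number from compound 3 to compound 4 (0.08 log units; within the scatter), and estimates compound 4 at 1000 nM, between 400 nM and 2500 nM.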

Compound 4, concentration for 50% growth inhibition: 768 nM
Compound 4: the middle estimate sits 1.3-fold (0.11 log units) above what was measured; measured number inside the range.
By their numbers in this assay, from the lowest: compounds 4, 1 and 3 (each within the scatter of the next); then compound 2.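

In this assay, hydrogen in place of methyl on the oxygen gives a 1.6-fold lower number from compound 3 to compound 4 (0.20 log units; within the scatter), so the methoxy and hydroxy forms cannot be told apart on this read-out. With the hydroxy group held in both compounds, trifluoromethyl in place of chloro gives a 1.2-fold lower number from compound 1 to compound 4 (0.08 log units; within the scatter), so these two groups cannot be told apart either. No measurement is at hand that bears on these results. From the compounds shown here alone, it remains open whether ethoxy on this oxygen, or an amine in place of the hydroxy group, would stay within the same range.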